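From methylsulfanyl to methyl on a shared core

The compounds below may be only part of what the source reports. "The series", "measured", "known", "first", "only" and "open" are said of these compounds alone.

Values from a functional assay on WM 266-4 cells (Homo sapiens) for antiproliferative activity, read by MTT assay, with a stated time of 24 h (a higher number here means a weaker inhibitor of growth, a lower number a stronger inhibitor of growth), so far:
- compound 1 `Fc1ccc(C2CC(c3ccc4c(c3)OCCO4)=NN2c2ccccc2)cc1` gives 6050 nM
- compound 2 `CSc1ccc(C2CC(c3ccc4c(c3)OCCO4)=NN2c2ccccc2)cc1` gives 6870 nM

For the measured compounds named here, compound 2 cannot be told apart from compound 1, the only other measured compound. Going by the values given here, the one step between them stays within the scatter (a 1.1-fold higher number from compound 1 to compound 2 (0.06 log units; within the scatter)). Compound 3 `Cc1ccc(C2CC(c3ccc4c(c3)OCCO4)=NN2c2ccccc2)cc1` keeps the shared core and alters one group (methyl in place of methylsulfanyl on an aromatic carbon): methyl in place of methylsulfanyl on an aromatic carbon, para to a large group. Among the compounds with values here, that single measured step, made at the same place, is the only one bearing on this change. No step beyond the scatter is therefore expected in this assay and no direction can be favoured. The expected step is small (a 1.1-fold lower number from compound 2 to compound 3 (0.03 log units; within the scatter)). For compound 3 an estimated 6400 nM is expected, with 3500 nM to 12000 nM as its range.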

Compound 3, concentration for 50% growth inhibition: 2530 nM
Beside the measured number, compound 3's estimate is 2.5-fold (0.40 log units) above it; measured number below the stated range.
By their numbers in this assay, from the lowest: compound 3; then compounds 1 and 2 (each within the scatter of the next).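

In this assay the group on this aromatic carbon, para to a large group, turns out to matter, which the earlier pair could not show: methyl in place of methylsulfanyl gives a 2.7-fold lower number from compound 2 to compound 3 (0.43 log units; beyond the scatter) and methyl in place of fluoro gives a 2.4-fold lower number from compound 1 to compound 3 (0.38 log units; beyond the scatter). Both steps are modest, yet they set compound 3 apart from compounds 1 and 2, whose values stay within the scatter of each other. No measurement available here gives a reason for this difference.

These compounds leave open whether a longer chain such as ethyl would follow methyl or fall back towards fluoro and methylsulfanyl. They also leave open what an amine or a carboxylic acid would do at this same place.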